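The source may report more compounds than this note shows. Statements on the series, on what has been measured and on what is new or still open speak of the compounds shown alone.

Three compounds have been measured in a functional assay on cells (Cancer cell lines, Homo sapiens) for cytotoxicity, read by sulforhodamine B assay, with a stated time of 48 h; a lower number here means a stronger inhibitor of growth, a higher number a weaker inhibitor of growth:

Compound 1, `COc1ccc(C2CC(c3ccccc3)=NN2C2=NC(=O)/C(=C3\C(=O)Nc4ccccc43)S2)cc1`, gives 1520 nM.
Compound 2, `COc1ccc(C2=NN(C3=NC(=O)/C(=C4\C(=O)Nc5ccccc54)S3)C(c3ccc(OC)cc3)C2)cc1`, gives 100000 nM.
Compound 3, `O=C1N=C(N2N=C(c3ccccc3)CC2c2ccc(Cl)cc2)S/C1=C1/C(=O)Nc2ccccc21`, gives 250 nM.

Compound 4, `COc1ccc(C2=NN(C3=NC(=O)/C(=C4\C(=O)Nc5ccccc54)S3)C(c3ccc(Cl)cc3)C2)cc1`, has not yet been measured in this assay.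

The change that turns compound 1 into compound 2 is methoxy in place of hydrogen on an aromatic carbon. The result was a 66-fold higher number from compound 1 to compound 2 (1.82 log units; beyond the scatter), a large loss of growth inhibition. Compound 3 differs from compound 1 by chloro in place of methoxy on an aromatic carbon, and this gave a 6.1-fold lower number from compound 1 to compound 3 (0.78 log units; beyond the scatter), so compound 3 stands lowest of the three. Compound 4 is built from compound 3 by methoxy in place of hydrogen on an aromatic carbon, the same change, made at a place described in the same words as for compound 1 and compound 2.

Within the data shown here, only one instance of this change has been measured, so the expectation rests on a single example. Because the step of a 66-fold higher number from compound 1 to compound 2 (1.82 log units; beyond the scatter) was large, the change made on compound 3 is expected to raise the number strongly as well, though perhaps not to the same extent, since the two cores differ by a chloro in place of a methoxy. For compound 4 the expected step is a 48-fold higher number from compound 3 to compound 4 (1.68 log units; beyond the scatter). The estimate for compound 4 in this assay is 12000 nM, with a range from 2500 nM to 60000 nM.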

Compound 4, concentration for 50% growth inhibition: 100000 nM
The estimate for compound 4 lay 8.3-fold (0.92 log units) below the measured number, and the stated range ends below it.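

In this assay, going from phenyl to 4-methoxyphenyl raised the number on both cores, and on the chloro core the new step is a 400-fold higher number from compound 3 to compound 4 (2.60 log units; beyond the scatter), so the direction carried over but the size did not: the same change on two cores in this assay, a 66-fold higher number (1.82 log units; beyond the scatter) from compound 1 to compound 2 and a 400-fold higher number (2.60 log units; beyond the scatter) from compound 3 to compound 4, 6.1-fold (0.78 log units) apart, beyond the scatter of two such steps

The reverse view tells the same story, since chloro in place of methoxy helped on the core of compound 1, yet with the 4-methoxyphenyl group present the step is no change at the digits printed from compound 2 to compound 4 (within the scatter), so that gain did not carry over either: the same change on two cores in this assay, a 6.1-fold lower number (0.78 log units; beyond the scatter) from compound 1 to compound 3 and no change at the digits printed (within the scatter) from compound 2 to compound 4, 6.1-fold (0.78 log units) apart, beyond the scatter of two such steps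

The two changes therefore do not add up independently in these four compounds, though this rests on just two pairs and does not show why the steps differ or whether the same holds elsewhere in the series.

The compounds shown leave open whether a smaller group at the same place, such as fluoro or hydroxyl, would be tolerated better than methoxy. They also leave open whether an amine or a longer chain such as ethoxy there would bring a similar rise in the number.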